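Acetyl on the Hydroxymethyl of Compound 1

This account rests on a few compounds, and the source may have more. Where it says the series, first, only, none or still open, it means among the compounds named here.

For the measured compounds named here, in a toxicity assay on Vero cells (Chlorocebus sabaeus) for cytotoxicity, with a stated time of 48 h (a lower number here means that less compound is tolerated, a higher number that more compound is tolerated), compound 1 `C=C1CC[C@@H]2[C@](C)(CO)[C@H](O)CC[C@@]2(C)[C@@H]1C/C=C1/C(=O)OC[C@H]1Oc1c(Cl)cc(Cl)c2cccnc12` gives 82500 nM, the only true number available so far. Compound 2 `C=C1CC[C@@H]2[C@](C)(CO)[C@H](O)CC[C@@]2(C)[C@@H]1C/C=C1/C(=O)OC[C@@H]1Oc1c(Cl)cc(Cl)c2cccnc12` is reported as > 100000 nM, which is a limit of the assay. Going by the values given here, the single measured step is an at least 1.2-fold higher number from compound 1 to compound 2 (0.08 log units; that floor lies within the scatter). It comes with the fact that compounds 1 and 2 differ only in the configuration as drawn, so it speaks to configuration and offers no guide to a new group.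

Compound 3 `C=C1CC[C@@H]2[C@](C)(COC(C)=O)[C@H](O)CC[C@@]2(C)[C@@H]1C/C=C1/C(=O)OC[C@H]1Oc1c(Cl)cc(Cl)c2cccnc12` keeps the core of compound 1 and carries acetyl in place of hydrogen on an oxygen on a saturated carbon, which reads as hydroxymethyl to acetoxymethyl. Among the compounds with values here, no measured step involves this change, so the data supply no size to carry over, and no shift beyond the scatter is expected in this assay. The expected change is a 1.1-fold lower number from compound 1 to compound 3 (0.04 log units; within the scatter), with its direction left open. For compound 3 the estimated value is 75000 nM, with an expected range from 30000 nM to 160000 nM.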

Compound 3, half-maximal cytotoxic concentration: 85000 nM
Compound 3: middle estimate off by 1.1-fold (0.05 log units), on the low side; the range from low to high includes it.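

In this assay, the change from hydroxymethyl to acetoxymethyl gives a 1.0-fold higher number from compound 1 to compound 3 (0.01 log units; within the scatter). For the compounds shown here, this is the first measured step at this position and the first to change a group instead of a configuration, and it shows that this acetyl on the oxygen leaves the number within the scatter of repeated measurements. Nothing known about these compounds bears on the reason for this result.

As far as these compounds go, whether the same would hold for a longer acyl group such as butanoyl or benzoyl, or for an amine or a carboxylic acid in place of the hydroxymethyl, remains open. From the compounds shown here alone, it also remains open how acetoxymethyl would behave in the configuration of compound 2, whose > 100000 nM is a limit of the assay and not a number.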